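A few compounds are considered here, and "the series" means these few. Any claim that something is new, unique, unknown or untested is made for them only; others in the source may bear on it.

Measured compounds:
- compound 1 `O=S(=O)(c1ccccc1)c1nc2ccccc2nc1N1CCc2ccccc2C1`: 18700 nM
- compound 2 `Cc1ccc(S(=O)(=O)c2nc3ccccc3nc2N2CCc3ccccc3C2)cc1`: 39000 nM
- compound 3 `O=S(=O)(c1ccccc1)c1nc2ccccc2nc1N1CCCC(O)C1`: 1390 nM

In a functional assay on HCT-116 cells (Homo sapiens) for cytotoxicity, read by MTT assay, with a stated time of 72 h (a lower number here means a stronger inhibitor, a higher number a weaker inhibitor), compound 3 gives the lowest number of the three, and its steps to compound 1 and compound 2 are both beyond the scatter. The difference between the core of compound 3 and the core of compound 1 is not broken down here. Compound 2 differs from compound 1 by methyl in place of hydrogen on an aromatic carbon, and this gave a 2.1-fold higher number from compound 1 to compound 2 (0.32 log units; beyond the scatter). Compound 4 `Cc1ccc(S(=O)(=O)c2nc3ccccc3nc2N2CCCC(O)C2)cc1` is unmeasured; it differs from compound 3 by methyl in place of hydrogen on an aromatic carbon, the same change at the same place. Because the earlier instance gave a 2.1-fold higher number from compound 1 to compound 2 (0.32 log units; beyond the scatter), a step of similar size is expected here, so compound 4 is estimated at a 2.1-fold higher number from compound 3 to compound 4 (0.32 log units; beyond the scatter) in this assay. Accordingly, compound 4 is expected at about 2900 nM, likely between 1200 nM and 7000 nM.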

Compound 4, half-maximal inhibitory concentration: 3270 nM
Estimate against measurement, compound 4: 1.1-fold (0.05 log units) below; measured number inside the range.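

In this assay, the change from phenyl to 4-methylphenyl behaved alike on both cores, giving a 2.4-fold higher number from compound 3 to compound 4 (0.37 log units; beyond the scatter), and the two instances agree: the same change on two cores in this assay, a 2.1-fold higher number (0.32 log units; beyond the scatter) from compound 1 to compound 2 and a 2.4-fold higher number (0.37 log units; beyond the scatter) from compound 3 to compound 4, 1.1-fold (0.05 log units) apart, within the scatter of two such steps. The other new step, a 12-fold lower number from compound 2 to compound 4 (1.08 log units; beyond the scatter), comes from 3-hydroxypiperidin-1-yl in place of 1,2,3,4-tetrahydroisoquinolin-2-yl with the 4-methylphenyl group kept, and it is large. Two pairs in one cell assay do not show that the methyl change would give a similar step on any other core.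

The compounds shown leave open what a chlorine, a methoxy group or a carboxylic acid would give in place of the methyl. Also open, going by these compounds, is what a piperidin-1-yl group lacking the hydroxy group would give.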